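The source may report more compounds than this note shows. Statements on the series, on what has been measured and on what is new or still open speak of the compounds shown alone.

Compound 1 `ClCc1cccc(Cn2cnc3ncnc(Cl)c32)c1` and compound 2 `ClCc1ccccc1Cn1cnc2ncnc(Cl)c21` are built from the same atoms joined differently; the difference between the two cores is not broken down here. In a functional assay on OVCAR-8 cells (Homo sapiens) for cytotoxicity, read by sulforhodamine B assay, with a stated time of 48 h (a higher number here means that more compound is tolerated, a lower number that less compound is tolerated), compound 1 gives 60300 nM, and compound 2 gives 58900 nM, the two values lying within the scatter of each other. Compound 3 `ClCc1cccc(Cn2cnc3nc(Cl)nc(Cl)c32)c1` carries one change relative to compound 1, (chloro in place of hydrogen on an aromatic carbon), and in this assay compound 3 gives 45700 nM. Compound 4 `ClCc1ccccc1Cn1cnc2nc(Cl)nc(Cl)c21` carries the same change relative to compound 2, (chloro in place of hydrogen on an aromatic carbon), with identical surroundings at the place of the change. Because compound 1 to compound 3 showed a 1.3-fold lower number from compound 1 to compound 3 (0.12 log units; within the scatter), the expected step in this assay is a 1.3-fold lower number from compound 2 to compound 4 (0.12 log units; within the scatter). Compound 4 is accordingly estimated at 45000 nM in this assay, with an expected range from 25000 nM to 80000 nM.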

Compound 4, concentration lethal to 50% of the cells: 75900 nM
Compound 4: middle estimate off by 1.7-fold (0.23 log units), on the low side; low and high end bracket the measured number.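

In this assay, chloro in place of hydrogen on an aromatic carbon gives a 1.3-fold higher number from compound 2 to compound 4 (0.11 log units; within the scatter), and the two cores compare as follows: the same change on two cores in this assay, a 1.3-fold lower number (0.12 log units; within the scatter) from compound 1 to compound 3 and a 1.3-fold higher number (0.11 log units; within the scatter) from compound 2 to compound 4, 1.7-fold (0.23 log units) apart, within the scatter of two such steps. On these two cores, the change leaves the number within the scatter, and the steps cannot be told apart, so carrying the step across them holds only in that limited sense. With two pairs and steps this small, the data show no clear effect of the change and say nothing about any further core.

The compounds shown leave open whether a different group on that carbon, such as an amine or a methoxy group, would shift the number beyond the scatter.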